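Benzyloxy in Place of Chloro on a Level Series

The source may report more compounds than this note shows. Statements on the series, on what has been measured and on what is new or still open speak of the compounds shown alone.

In a functional assay on the whole organism for inhibition, with Felis catus as the target, with a stated time of 30 min (a lower number here means that less compound is needed, a higher number that more compound is needed for the effect), compound 2 `OC(CNCCOc1ccc(Cl)cc1)COc1ccccc1` gives 0.08 mg/kg and stands level with its two measured neighbours. Compound 1 `COc1ccc(OCCNCC(O)COc2ccccc2)cc1` gives 0.064 mg/kg with methoxy where compound 2 carries chloro. Compound 3 `OC(CNCCOc1ccccc1F)COc1ccccc1` gives 0.081 mg/kg with 2-fluorophenyl in place of 4-chlorophenyl on the oxygen.

Compound 4 `OC(CNCCOc1ccc(OCc2ccccc2)cc1)COc1ccccc1` has not yet been measured and differs from compound 2 as follows: benzyloxy in place of chloro on an aromatic carbon with benzyloxy in place of chloro on an aromatic carbon. Within the data shown here, compound 1 is the closest guide, as its methoxy stands on that same aromatic carbon, and the change there gave a 1.3-fold higher number from compound 1 to compound 2 (0.10 log units; within the scatter) in the only measured step at this place. The change of the whole aryl group gave a 1.0-fold higher number from compound 2 to compound 3 (0.01 log units; within the scatter) and is just as small. Among the measured compounds shown here, no measured compound carries a second aromatic ring in this group, so the data do not show how far a substituent of this size would carry. A small step is therefore expected, leaning slightly towards a higher number, and the estimated change is a 1.3-fold higher number from compound 2 to compound 4 (0.10 log units; within the scatter) with no move beyond the scatter anticipated. For compound 4 the estimated value is 0.1 mg/kg with an expected range from 0.04 mg/kg to 0.3 mg/kg for this measurement.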

Compound 4, dose for half-maximal effect: 0.534 mg/kg
Compound 4: the middle estimate sits 5.3-fold (0.73 log units) below what was measured; measured number above the stated range.
By their numbers in this assay, from the lowest: compounds 1, 2 and 3 (each within the scatter of the next); then compound 4.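

In this assay, the aromatic carbon para to a large group proves sensitive to what it carries: benzyloxy in place of chloro gives a 6.7-fold higher number from compound 2 to compound 4 (0.82 log units; beyond the scatter), whereas the exchange between methoxy and chloro at the same carbon gave only a 1.3-fold higher number from compound 1 to compound 2 (0.10 log units; within the scatter), within the scatter. Phenyl in place of hydrogen on the saturated chain carbon bound to the oxygen gives an 8.3-fold higher number from compound 1 to compound 4 (0.92 log units; beyond the scatter), so a step beyond the scatter appears at this position once the substituent carries a second aromatic ring, and more compound is then needed for the effect. Nothing available explains this rise in the number, and the size of the step is all that can be stated.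

The compounds shown leave open whether the rise follows the phenyl ring itself or simply the length of the substituent, a question that an ethoxy or butoxy chain on the same carbon would address. They also leave open how far the benzyloxy group can be altered, for instance with a hydroxyl or an amine on its phenyl ring, or with phenoxy in its place.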